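The compounds below may be only part of what the source reports. "The series", "measured", "known", "first", "only" and "open" are said of these compounds alone.

Compound 1 `C[C@@H]1O[C@@H](n2c3ccccc3c3c4c(c5c6ccccc6ccc5c32)C(=O)NC4=O)[C@H](O)[C@H](O)[C@H]1O` gives 2800 nM in a functional assay on A549 cells (Homo sapiens) for cytotoxicity; on this read-out lower numbers stand for stronger inhibition and higher numbers for weaker inhibition.
Compound 2 `O=C1NC(=O)c2c1c1c3ccccc3ccc1c1c2c2ccccc2n1[C@H]1OC[C@@H](O)[C@@H](O)[C@H]1O` gives 2000 nM.
Compound 3 `O=C1NC(=O)c2c1c1c3ccccc3ccc1c1c2c2ccccc2n1[C@@H]1O[C@H](CO)[C@@H](O)[C@H]1O` gives 2100 nM.

Compound 3 stands second highest of these three numbers, but its neighbours are close: a 1.1-fold higher number from compound 2 to compound 3 (0.02 log units; within the scatter) and a 1.3-fold lower number from compound 1 to compound 3 (0.12 log units; within the scatter) both lie within the scatter, so the three compounds cannot be told apart. Compound 4 `O=C1NC(=O)c2c1c1c3ccccc3ccc1c1c2c2ccccc2n1[C@H]1C[C@H](O)[C@@H](CO)O1` is compound 3 with hydrogen in place of hydroxy on a saturated ring carbon. Within the data shown here, no measured step removes a hydroxy group outright, so the closest guides are the three exchanges of the whole sugar part on the aromatic nitrogen: a 1.4-fold lower number from compound 1 to compound 2 (0.15 log units; within the scatter), a 1.3-fold lower number from compound 1 to compound 3 (0.12 log units; within the scatter) and a 1.1-fold higher number from compound 2 to compound 3 (0.02 log units; within the scatter), every one within the scatter. Because a 1.3-fold lower number from compound 1 to compound 3 (0.12 log units; within the scatter) stayed within the scatter while changing far more of the sugar, compound 4 is expected to stay close to compound 3, with no change at the digits printed from compound 3 to compound 4 (within the scatter). Compound 4 is therefore estimated at 2100 nM, in a range from 800 nM to 5500 nM.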

Compound 4, half-maximal inhibitory concentration: 3400 nM
The estimate for compound 4 lay 1.6-fold (0.21 log units) below the measured number; measured number inside the range.
By their numbers in this assay, from the lowest: compounds 2, 3, 1 and 4 (each within the scatter of the next).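

In this assay the loss of this one hydroxy from the five-membered ring gives a 1.6-fold higher number from compound 3 to compound 4 (0.21 log units; within the scatter) and thus no change that can be told from the scatter. The same holds against the other sugars, with a 1.7-fold higher number from compound 2 to compound 4 (0.23 log units; within the scatter) and a 1.2-fold higher number from compound 1 to compound 4 (0.08 log units; within the scatter) as the remaining steps, so compound 4 cannot be told apart from any of the three earlier compounds. Nothing measured here gives a reason for this result.

Going by these compounds, whether an amine or a methoxy group on this ring carbon would move the number beyond the scatter stays open, as does the outcome for a sugar with no hydroxy group left on the ring.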